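The compounds below may be only part of what the source reports. "The series", "measured", "known", "first", "only" and "open" are said of these compounds alone.

Measured in an ADME assay on microsomes from liver (Rattus norvegicus, strain Sprague-Dawley) for metabolic stability, read by LC-MS, using NADPH, with a stated time of 45 min, tested at 3 uM; on this read-out higher numbers stand for a longer-lived compound and lower numbers for a shorter-lived compound:
- Compound 1 `C1CCC(C(CC2CCCCN2)C2CCCC2)CC1`: 0.317 h
- Compound 2 `Fc1ccc(C(CC2CCCCN2)C2CCCCC2)cc1`: 0.117 h

Compound 2 has the lower of the two numbers, 0.117 h, and compound 1 stands higher at 0.317 h. The next compound to consider is compound 3 `FC1CCC(C(CC2CCCCN2)C2CCCCC2)CC1`. The change is 4-fluorocyclohexyl in place of 4-fluorophenyl on a saturated chain carbon bound to a saturated chain carbon and a saturated ring carbon. Among the measured compounds shown here, only one measured step bears on this: a 2.7-fold lower number from compound 1 to compound 2 (0.43 log units; beyond the scatter). There, an aromatic ring replaced a non-aromatic one and the number fell. The new change runs the other way, from aromatic to non-aromatic, but a single step is thin evidence. A modest rise in this assay is therefore expected, and the expected change is a 2.1-fold higher number from compound 2 to compound 3 (0.33 log units; beyond the scatter). The estimate for compound 3 is 0.25 h, with an expected range from 0.11 h to 0.55 h.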

Compound 3, half-life: 0.183 h
Estimate against measurement, compound 3: 1.4-fold (0.14 log units) above, within the range that was stated.
By their numbers in this assay, from the lowest: compounds 2, 3 and 1 (each within the scatter of the next, the first and the last beyond it).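

At this position on a saturated chain carbon, trading the flat aromatic ring for a saturated ring of the same size, with the fluorine kept, gives a 1.6-fold higher number from compound 2 to compound 3 (0.19 log units; within the scatter) in this assay, so the two fluorinated rings cannot be told apart here. The other comparison gives a 1.7-fold lower number from compound 1 to compound 3 (0.24 log units; within the scatter), so 4-fluorocyclohexyl also cannot be told apart from cyclopentyl, even though the step between the two earlier compounds lies beyond the scatter: compound 3 sits within reach of both. No measurement shown here explains why these half-lives fall where they do.

Going by these compounds, the part played by the fluorine itself remains open, as a plain phenyl ring at this position would be needed to separate it from the ring change. On these data alone, how a more different group, such as a hydroxyl or a carboxylic acid on the ring, would behave also remains unknown.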